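The source may report more compounds than this note shows. Statements on the series, on what has been measured and on what is new or still open speak of the compounds shown alone.

Compound 1 `CCc1ccc(Nc2nc3nonc3nc2O)cc1` is measured in an assay on mitochondria from L6 cells (Rattus norvegicus) for activation, with a stated time of 90 min (on this read-out lower numbers stand for an effect already at smaller amounts and higher numbers for an effect only at larger amounts of compound), where compound 1 gives 10700 nM. Among the three measured compounds this is the second highest number. Compound 2 `CCc1ccc(Nc2nc3nonc3nc2O)c(F)c1`, which in this assay gives 6700 nM, is the nearest, and the step of a 1.6-fold lower number from compound 1 to compound 2 (0.20 log units; within the scatter) stays within the scatter; the change there is fluoro in place of hydrogen on an aromatic carbon. Among the measured compounds shown here, compound 3 `Cc1ccc(CNc2nc3nonc3nc2O)cc1` is the furthest, giving 53200 nM in this assay, a higher number than compound 1 shows, though these two differ in more than one place and no single step links them. Compound 4 `Oc1nc2nonc2nc1Nc1ccc(OC(F)F)cc1` differs from compound 1 in one place: difluoromethoxy in place of ethyl on an aromatic carbon. For the measured compounds named here, no measured step replaces the ethyl group, so the only guide is the fluoro step, which stayed within the scatter. The step of a 1.2-fold lower number from compound 1 to compound 4 (0.08 log units; within the scatter) is therefore expected to be small, with no clear direction. For compound 4 the estimate in this assay is 9000 nM, with a range from 3000 nM to 30000 nM.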

Compound 4, half-maximal effective concentration: 20600 nM
Beside the measured number, compound 4's estimate is 2.3-fold (0.36 log units) below it, and the stated range covers the measured number.
By their numbers in this assay, from the lowest: compounds 2, 1 and 4 (each within the scatter of the next, the first and the last beyond it); then compound 3.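

In this assay, putting difluoromethoxy in place of ethyl gives a 1.9-fold higher number from compound 1 to compound 4 (0.28 log units; within the scatter) and so stays within the usual scatter. This is the only step shown at the aromatic carbon para to a large group, since the earlier fluoro step changed a different aromatic carbon. It shows that, in this read-out, this position can hold a group with more heavy atoms and a hydrogen-bond acceptor, which ethyl lacks, without a change that can be told from repeat-measurement noise, and no supporting measurement explains this result.

A single step cannot show whether this position is generally tolerant or whether these two groups merely happen to give similar numbers. As far as these compounds go, it remains open whether an amine, a carboxylic acid or a longer alkyl chain at this carbon would move the number beyond the scatter.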